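The compounds below may be only part of what the source reports. "The series", "measured", "known", "first", "only" and "open" are said of these compounds alone.

In an ADME assay on HEK293 cells (Homo sapiens) for cytotoxicity, read by ATP content, with a stated time of 6 h (a lower number here means that less compound is tolerated, a higher number that more compound is tolerated), compound 1 `CCCCNc1nc(N)nc2ccn(CC(=O)NC)c12` gives > 24000 nM, a limit of the assay. Compound 2 `CCCCNc1nc(N)nc2ccn(Cc3ccccn3)c12` gives > 24000 nM, likewise a limit. Among the measured compounds shown here, the one measured step, a step that the two limits leave unreadable from compound 1 to compound 2, has no size to carry forward, and the only evidence is the limit of > 24000 nM in this assay, at which 2 of the 2 values shown sit. Compound 3 `CCCCNc1nc(N)nc2ccn(Cc3ncccc3OC)c12` differs from compound 2 by methoxy in place of hydrogen on an aromatic carbon, with methoxy in place of hydrogen on an aromatic carbon. For the measured compounds named here, with no sized step available, no step beyond the scatter is expected in this assay, and another limit is the likeliest report. The estimated value for compound 3 is 24000 nM, with an expected range of 12000 nM to 36000 nM. The expected step is a number no higher from compound 2 to compound 3 (the limit leaves the size open).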

Compound 3, half-maximal cytotoxic concentration: > 24000 nM
Compound 3: a limit, no number; the forecaster's own chance of this, stated with the estimate: 85%; the middle value lies on the limit itself.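

No step can be read among compound 1, compound 2 and compound 3 in this assay, since all three report the same limit: the limit of > 24000 nM in this assay, at which 3 of the 3 values shown sit.
The compounds shown leave open at what concentration any of them reduces ATP content, and whether methoxy in place of hydrogen alters that concentration.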